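A few compounds are considered here, and "the series" means these few. Any claim that something is new, unique, unknown or untested is made for them only; others in the source may bear on it.

Measured compounds: compound 1 `COc1ccc(-c2cc3c(OC)cc(OC)cc3n(C)c2=O)cc1` with 10000 nM in a functional assay on T-24 cells (Homo sapiens) for cytotoxicity, read by colorimetric assay and MTT assay (on this read-out lower numbers stand for stronger inhibition and higher numbers for weaker inhibition), and compound 2 `CCN(CC)C(=O)CCn1c(=O)c(-c2ccc(OC)cc2)cc2c(OC)cc(OC)cc21` with 10000 nM.

Compound 1 stands level with compound 2 on these numbers, the step of no change at the digits printed from compound 1 to compound 2 (within the scatter) lying within the scatter. Compound 3 `COc1cc(OC)c2cc(-c3ccc(OC(C)=O)cc3)c(=O)n(C)c2c1` differs from compound 1 by acetyl in place of methyl on an oxygen on an aromatic ring. For the measured compounds named here, no measured step touches this oxygen; the only step recorded, from compound 1 to compound 2, alters a different place and shows nothing. With no guide either way, compound 3 is expected to stay near compound 1, the estimated step being no change at the digits printed from compound 1 to compound 3 (within the scatter). Compound 3 is therefore estimated at 10000 nM, in the range 4000 nM to 25000 nM.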

Compound 3, half-maximal inhibitory concentration: 10000 nM
Compound 3: the middle estimate sits on the measured number at the digits printed; the measured number falls inside the stated range.
By their numbers in this assay, from the lowest: compounds 1, 2 and 3 (each within the scatter of the next).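

In this assay, acetyl in place of methyl on an oxygen on an aromatic ring gives no change at the digits printed from compound 1 to compound 3 (within the scatter). This oxygen, untouched by the earlier step, now has a reading of its own: the larger acetyl group, with its hydrogen-bond acceptor, leaves the number where it stood. No available evidence bears on why the number holds. As far as these compounds go, whether a free hydroxyl or a longer chain ending in an amine on this oxygen would move the number stays open. So does whether any group on the shared core would.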